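This account rests on a few compounds, and the source may have more. Where it says the series, first, only, none or still open, it means among the compounds named here.

Compound 1 `C#CCSc1cnc2ccccc2c1[Se]CC#CCCl` and compound 2 `CSc1cnc2ccccc2c1[Se]CC#CCCl` share one core. In a functional assay on T47D cells (Homo sapiens) for antiproliferative activity, with a stated time of 72 h (on this read-out higher numbers stand for weaker inhibition and lower numbers for stronger inhibition), compound 1 gives 0.4 ug/mL, and compound 2 gives 0.7 ug/mL. The change from compound 1 to compound 2 is hydrogen in place of ethynyl on a saturated chain carbon bound to a sulfur, and it made a 1.8-fold higher number from compound 1 to compound 2 (0.24 log units; within the scatter). Compound 3 `C#CCSc1cnc2ccccc2c1SCC#CCCl` stands on a different core; how the two cores differ is a group of 6 heavy atoms (4 carbon, 1 sulfur, 1 chlorine; no ring) in place of a group of 6 heavy atoms (4 carbon, 1 chlorine, 1 selenium; no ring), on an aromatic carbon, and that exchange made a 15-fold higher number from compound 1 to compound 3 (1.16 log units; beyond the scatter). In this assay compound 3 gives 5.8 ug/mL. Going by the values given here, compound 4 `CSc1cnc2ccccc2c1SCC#CCCl` has not yet been measured; it differs from compound 3 by hydrogen in place of ethynyl on a saturated chain carbon bound to a sulfur, the same change as the one from compound 1 to compound 2. Because that change made a 1.8-fold higher number from compound 1 to compound 2 (0.24 log units; within the scatter), a step of about a 1.7-fold higher number from compound 3 to compound 4 (0.24 log units; within the scatter) is expected here. The estimate for compound 4 in this assay is 10 ug/mL.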

Compound 4, concentration for 50% inhibition: 3.9 ug/mL
The estimate for compound 4 lay 2.6-fold (0.41 log units) above the measured number, outside the stated range (below it).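

Replacing propargyl with methyl on the sulfur gives a 1.5-fold lower number from compound 3 to compound 4 (0.17 log units; within the scatter), and this step matches the same change on the selenium-containing core: the same change on two cores in this assay, a 1.8-fold higher number (0.24 log units; within the scatter) from compound 1 to compound 2 and a 1.5-fold lower number (0.17 log units; within the scatter) from compound 3 to compound 4, 2.6-fold (0.42 log units) apart, within the scatter of two such steps. Exchanging the selenium-containing group for the sulfur-containing group gives a 5.6-fold higher number from compound 2 to compound 4 (0.75 log units; beyond the scatter), and this step also matches its earlier counterpart: the same change on two cores in this assay, a 15-fold higher number (1.16 log units; beyond the scatter) from compound 1 to compound 3 and a 5.6-fold higher number (0.75 log units; beyond the scatter) from compound 2 to compound 4, 2.6-fold (0.42 log units) apart, within the scatter of two such steps. In this assay, each change therefore carries across these two cores within the scatter, but four compounds in a single assay do not show that this would hold on any other core, nor do they explain why either step has its size.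

From the compounds shown here alone, it remains open how a longer chain or an amine in place of methyl on the sulfur would behave. It is also unknown whether a hydroxyl group in place of the chlorine would alter either step.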